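Swapping a methylphenyl arm for isobutyl on two cores

The compounds below may be only part of what the source reports. "The series", "measured", "known", "first", "only" and "open" are said of these compounds alone.

Measured in an assay on isolated protein for inhibition of aldehyde dehydrogenase 1A1 (Homo sapiens), read by spectrophotometry, tested at 10 uM; on this read-out lower numbers stand for less inhibition and higher numbers for more inhibition at the one concentration tested (going by the name of the read-out):

Compound 1, `CC(C)CCn1c(CN2CCN(C(=O)c3ccco3)CC2)nc2ccccc21`: 42.1%
Compound 2, `Cc1cccc(Cn2c(OC3CCN(C(=O)C4CC4)CC3)nc3ccccc32)c1`: 80.6%
Compound 3, `Cc1cccc(Cn2c(CN3CCN(C(=O)c4ccco4)CC3)nc3ccccc32)c1`: 73.2%

Compound 1 and compound 3 share one core and differ in a single place: isobutyl in place of 3-methylphenyl on a saturated chain carbon bound to an aromatic nitrogen. In this assay this change made a number 31.1 percentage points lower from compound 3 to compound 1 (beyond the scatter), a drop that goes well beyond the usual scatter of repeated measurements.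

Compound 2 is built on a different core. The difference between the core of compound 2 and the core of compound 3 is not broken down here, so the two cannot be compared piece by piece; their values in this assay lie within the scatter of each other.

Compound 4, `CC(C)CCn1c(OC2CCN(C(=O)C3CC3)CC2)nc2ccccc21`, has not yet been measured. It stands to compound 2 as compound 1 stands to compound 3: isobutyl in place of 3-methylphenyl on a saturated chain carbon bound to an aromatic nitrogen. The place of the change is the same in both pairs, so this is the same change, now carried out on the core of compound 2.

If the change behaves on this second core as it did on the first, a step of similar size is expected, a number 31.1 percentage points lower from compound 2 to compound 4 (beyond the scatter), resting on the step of a number 31.1 percentage points lower from compound 3 to compound 1 (beyond the scatter) seen between the measured pair. On that basis compound 4 is estimated at 49.5% in this assay. For the measured compounds named here, only one earlier example of the change exists, so the estimate for compound 4 is given a wide span, from 30% to 68%.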

Compound 4, a percentage reported as inhibition, at one concentration (the size of the read-out at that concentration, not a potency): 56.4%
Compound 4: the middle estimate sits 6.9 percentage points below what was measured, within the range that was stated.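

On the core of compound 2, isobutyl in place of 3-methylphenyl gave a number 24.2 percentage points lower from compound 2 to compound 4 (beyond the scatter) in this assay. Set beside the earlier pair, the change points the same way on both cores, and the two steps do not differ in size by more than repeated measurements could explain: the same change on two cores in this assay, a number 31.1 percentage points lower (beyond the scatter) from compound 3 to compound 1 and a number 24.2 percentage points lower (beyond the scatter) from compound 2 to compound 4, 6.9 percentage points apart, within the scatter of two such steps

This shows that, in these two pairs, the effect of the swap carries from one core to the other, but two cores are a small sample and do not show that it would hold on any further core, and nothing here explains why the isobutyl compounds read lower. Each number is also a single percentage at one concentration, so it does not show how the change affects potency.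

In both pairs the aromatic ring and its methyl leave together, so the compounds shown cannot tell whether the ring, the methyl or both matter. From the compounds shown here alone, a plain benzyl group would bear on that question, while a longer chain or a chain ending in an amine at the same place remains open as well.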